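A few compounds are considered here, and "the series" means these few. Any claim that something is new, unique, unknown or untested is made for them only; others in the source may bear on it.

Compound 2, `C[C@@H](NC(=O)c1ccc(C#Cc2cccc(F)n2)cn1)C(C)(C)O`, and compound 1, `C[C@@H](NC(=O)c1ccc(C#CC2CC2)cn1)C(C)(C)O`, share one core and differ only in the group on the triple-bonded carbon. In a functional assay on HEK293 cells for positive allosteric modulation of metabotropic glutamate receptor 5 (Rattus norvegicus), read by fluorescence and calcium flux (a higher number here means a larger maximal response, a lower number a smaller maximal response), compound 1 gives 63.4%, and compound 2 gives 63%. Among these two numbers compound 2 sits alongside compound 1, since the step of a number 0.4 percentage points lower from compound 1 to compound 2 (within the scatter) lies within the scatter and separates nothing. Compound 3, `C[C@@H](NC(=O)c1ccc(C#Cc2ccc(F)cn2)cn1)C(C)(C)O`, arises from compound 2 by the change (5-fluoropyridin-2-yl in place of 6-fluoropyridin-2-yl on a triple-bonded carbon). For the measured compounds named here, the only measured step at this place, a number 0.4 percentage points lower from compound 1 to compound 2 (within the scatter), exchanged a cyclopropyl for a 6-fluoropyridin-2-yl without moving the number beyond the scatter; a rearrangement of the same atoms within the pyridinyl has no measured precedent here. For compound 3 the expected step is therefore no change at the digits printed from compound 2 to compound 3 (within the scatter), none beyond the scatter. Compound 3 is estimated to give 63% in this assay, within a range from 50% to 76%.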

Compound 3, largest response reached (reported as efficacy), in percent of the reference or control that the assay uses: 64.6%
Compound 3: middle estimate off by 1.6 percentage points, on the low side; the range from low to high includes it.
By their numbers in this assay, from the lowest: compounds 2, 1 and 3 (each within the scatter of the next).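

In this assay, the fluorine can sit in either printed arrangement on the pyridinyl ring without separating the compounds: 5-fluoropyridin-2-yl in place of 6-fluoropyridin-2-yl gives a number 1.6 percentage points higher from compound 2 to compound 3 (within the scatter). The exchange of cyclopropyl for 5-fluoropyridin-2-yl gives a number 1.2 percentage points higher from compound 1 to compound 3 (within the scatter), so a second fluoropyridinyl group also stays level with the cyclopropyl compound, and the three groups on the triple-bonded carbon cannot be told apart by maximal response. No supporting observation is available to account for this sameness.

Going by these compounds, whether the response stays level with a group of a different kind on the triple-bonded carbon, such as an amine, a carboxylic acid or a longer alkyl chain, remains open. So does the effect of unsubstituted pyridin-2-yl, which would show whether the fluorine matters at all.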